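Growth inhibition at the assay limit: compound 2 to compound 3

A few compounds are considered here, and "the series" means these few. Any claim that something is new, unique, unknown or untested is made for them only; others in the source may bear on it.

In a functional assay (786-0 cells, Homo sapiens) for inhibition, read by sulforhodamine B assay, with a stated time of 48 h (a higher number here means a weaker inhibitor of growth, a lower number a stronger inhibitor of growth), compound 1 `O=C(Cc1csc2nc(-c3ccc(Br)cc3)cn12)N/N=C/c1ccccc1` gives > 100000 nM, which is a limit of the assay and not a number.

Compound 2 `COc1cccc(OC)c1/C=N/NC(=O)Cc1csc2nc(-c3ccc(Br)cc3)cn12` gives > 100000 nM, which is also a limit, so its position is known only as a limit.

Among the measured compounds shown here, the series so far offers (the limit of > 100000 nM in this assay, at which 2 of the 2 values shown sit).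

For the measured compounds named here, the single measured step, a step that the two limits leave unreadable from compound 1 to compound 2, has no readable size and gives no magnitude to carry forward.

Compound 3 `O=C(Cc1csc2nc(-c3ccc(Br)cc3)cn12)N/N=C/c1ccc(Cl)cc1Cl` is the next structure, with 2,4-dichlorophenyl in place of 2,6-dimethoxyphenyl on a carbon with a double bond to nitrogen.

Going by the values given here, no measured step covers this exchange, so the expectation is weak. The most likely outcome is another reading at the limit. If a number does appear in this assay, it is expected to lie on the stronger side of the limit of compound 2, and only modestly so.

The expected step is an at least 1.4-fold lower number from compound 2 to compound 3 (0.15 log units; that floor lies within the scatter).

For compound 3 the estimated value is 70000 nM, with an expected range of 20000 nM to 100000 nM.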

Compound 3, concentration for total growth inhibition: 74100 nM
The estimate for compound 3 lay 1.1-fold (0.02 log units) below the measured number, within the range that was stated.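

In this assay compound 3 is the only one of the three to give a number and not a limit, so 2,4-dichlorophenyl is the only group shown on a carbon with a double bond to nitrogen that has a readable result. In place of 2,6-dimethoxyphenyl it gives an at least 1.3-fold lower number from compound 2 to compound 3 (0.13 log units; that floor lies within the scatter), and in place of phenyl it gives an at least 1.3-fold lower number from compound 1 to compound 3 (0.13 log units; that floor lies within the scatter); both are floors, and the step between the two compounds at the limit cannot be read. Going by these compounds, the true size of either step therefore stays unknown, and the series still sits mostly at one end of the assay's range: the limit of > 100000 nM in this assay, at which 2 of the 3 values shown sit.

The compounds shown do not tell whether both chlorine atoms are needed for a number to appear, or whether a phenyl carrying a single chlorine would also give one. Also open, on these data alone, is how a phenyl bearing an amine or a carboxylic acid at this place would read, and whether any change to the core of compound 3 would move the number beyond the scatter.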